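Cytotoxicity Stays Beyond Reach Across Three Biaryl Amides

A few compounds are considered here, and "the series" means these few. Any claim that something is new, unique, unknown or untested is made for them only; others in the source may bear on it.

Measured compounds:
compound 1 `CC(=O)c1cccc(-c2ccc(C(=O)N(Cc3cccc(OCCCCCC(=O)O)c3)C(C)C)cc2)c1` — > 26000 nM
compound 2 `CC(C)N(Cc1cccc(OCCCCCC(=O)O)c1)C(=O)c1ccc(-c2ccc3c(c2)OCCO3)cc1` — > 21900 nM

Both compounds share one core and differ only in the aryl group on the far ring. In an ADME assay on BJ cells (Homo sapiens) for cytotoxicity, read by CellTiter-Glo and resazurin assay, with a stated time of 72 h (a lower number here means that less compound is needed, a higher number that more compound is needed for the effect), compound 1 gives > 26000 nM, which is a limit of the assay and not a number. In this assay compound 2 gives > 21900 nM, likewise a limit. Putting 2,3-dihydro-1,4-benzodioxin-6-yl in place of 3-acetylphenyl therefore yields a step that the two limits leave unreadable from compound 1 to compound 2; the two limits the limit of > 21900 nM in this assay, at which 1 of the 2 values shown sits, and the limit of > 26000 nM in this assay, at which 1 of the 2 values shown sits, leave nothing to read about size or direction.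

Compound 3 `CC(C)N(Cc1cccc(OCCCCCC(=O)O)c1)C(=O)c1ccc(-c2c[nH]c3ccccc23)cc1` differs from compound 2 by 1H-indol-3-yl in place of 2,3-dihydro-1,4-benzodioxin-6-yl on an aromatic carbon. Among the compounds with values here, no measured step gives a readable size, so the only guide is that neither measured compound showed cytotoxicity within range. Compound 3 is therefore expected to remain near the top of the window, at an estimated 25000 nM with a range from 9000 nM to 60000 nM, and the expected step is a step that the limit leaves unreadable from compound 2 to compound 3.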

Compound 3, half-maximal effective concentration: > 26000 nM
Compound 3: only a limit was reported; the forecaster's own chance of this, stated with the estimate: 70%; at least 1.0-fold (0.01 log units) between middle value and limit.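

Within the data shown here, compound 3, like compound 1 and compound 2, gives only a limit and not a number in this assay, and no step among the three can be read. Open remains at what concentration each compound would reach the effect, and whether the three aryl groups differ there.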